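Thiophen-2-yl for 4-methoxyphenyl in compound 3

The compounds below may be only part of what the source reports. "The series", "measured", "known", "first", "only" and "open" are said of these compounds alone.

In a functional assay on HT-29 cells (Homo sapiens) for inhibition, read by MTT assay, with a stated time of 48 h (a higher number here means a weaker inhibitor, a lower number a stronger inhibitor), compound 2 `COc1cc(-c2cc(-c3ccccc3)nc(-c3ccccc3)n2)cc(OC)c1OC` gives 7930 nM and compound 3 `COc1ccc(-c2cc(-c3cc(OC)c(OC)c(OC)c3)nc(-c3ccccc3)n2)cc1` gives 4230 nM, two values within the scatter of each other. For compound 1 `COc1cc(-c2cc(-c3cccc([N+](=O)[O-])c3)nc(-c3ccccc3)n2)cc(OC)c1OC`, the result is a limit, > 25000 nM.

Compound 4 `COc1cc(-c2cc(-c3cccs3)nc(-c3ccccc3)n2)cc(OC)c1OC` carries thiophen-2-yl in place of 4-methoxyphenyl on an aromatic carbon. Two measured steps, an at least 3.1-fold lower number from compound 1 to compound 2 (0.49 log units; beyond the scatter) and an at least 5.9-fold lower number from compound 1 to compound 3 (0.77 log units; beyond the scatter), lie beyond the scatter but start from that limit, and both remove the nitro-bearing compound 1. The closest guide is a 1.9-fold lower number from compound 2 to compound 3 (0.27 log units; within the scatter), methoxy in place of hydrogen, which stays within the scatter. No step beyond the scatter is therefore expected in this assay, and the estimated step is a 1.4-fold higher number from compound 3 to compound 4 (0.15 log units; within the scatter). For compound 4, the estimated value is 6000 nM, with an expected range of 2500 nM to 14000 nM.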

Compound 4, half-maximal inhibitory concentration: > 25000 nM
Compound 4: only a limit was reported; the forecaster's own chance of this, stated with the estimate: 8%; at least 4.1-fold (0.61 log units) between middle value and limit.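

In this assay, thiophen-2-yl on this aromatic carbon gives an at least 5.9-fold higher number from compound 3 to compound 4 (0.77 log units; beyond the scatter) and an at least 3.1-fold higher number from compound 2 to compound 4 (0.49 log units; beyond the scatter), so a loss beyond the scatter at this position no longer belongs to the nitro-bearing compound 1 alone. On these data alone, both steps start or end on a limit for compound 4, so their true size stays unknown. The step between compound 1 and compound 4 cannot be read, as both values are limits: the limit of > 25000 nM in this assay, at which 2 of the 4 values shown sit.

Open, as far as these compounds go, is whether furan-2-yl or pyridin-3-yl at this position would come back under that limit. Also open, from the compounds shown here alone, is whether an amine or a carboxylic acid on the phenyl group would change the value.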